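This account rests on a few compounds, and the source may have more. Where it says the series, first, only, none or still open, it means among the compounds named here.

Series notes, amide-aryl variation on the shared core.

Compound 1 `Cc1ccccc1C(=O)Nc1cccc(-c2oc3cc(-c4ccc(F)cc4)ccc3c(=O)c2O)c1` in a functional assay on HepG2 cells (Homo sapiens) for antiproliferative activity, read by CCK-8 assay, with a stated time of 72 h (on this read-out lower numbers stand for stronger inhibition and higher numbers for weaker inhibition), gives 19400 nM. Compound 3 `COc1ccc(C(=O)Nc2cccc(-c3oc4cc(-c5ccc(F)cc5)ccc4c(=O)c3O)c2)c(F)c1` in this assay gives 45300 nM, the higher of the two numbers present, the nearest being compound 1 with a 2.3-fold higher number from compound 1 to compound 3 (0.37 log units; beyond the scatter). Compound 2 `O=C(Nc1cccc(-c2oc3cc(-c4ccc(F)cc4)ccc3c(=O)c2O)c1)c1ccc(Br)cc1F` in this assay sits at a limit, > 100000 nM, which is a limit of the measurement and not a number. The step from compound 1 to compound 2 reads an at least 5.1-fold higher number from compound 1 to compound 2 (0.71 log units; beyond the scatter), and that from compound 2 to compound 3 reads an at least 2.2-fold lower number from compound 2 to compound 3 (0.34 log units; beyond the scatter); both are bounded by the limit of > 100000 nM in this assay, at which 1 of the 3 values shown sits.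

Compound 4 `O=C(Nc1cccc(-c2oc3cc(-c4ccc(F)cc4)ccc3c(=O)c2O)c1)c1ccc(Cl)nc1` is not yet measured. Compared with compound 3 it carries 6-chloropyridin-3-yl in place of 2-fluoro-4-methoxyphenyl on a carbonyl carbon. The three measured steps all concern the ring on this carbonyl carbon, and the one ring bearing a halogen at the position remote from the carbonyl, compound 2, went to the limit. On that basis a higher number than compound 3 is expected in this assay, possibly again at the limit.

For compound 4 the expected step is a 1.8-fold higher number from compound 3 to compound 4 (0.25 log units; within the scatter), giving an estimated 80000 nM in this assay, with a range from 30000 nM to 250000 nM.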

Compound 4, half-maximal inhibitory concentration: 4610 nM
Compound 4: middle estimate off by 17-fold (1.24 log units), on the high side; the measured number lies below the stated range.
By their numbers in this assay, from the lowest: compound 4; then compound 1; then compound 3. At a limit, above all of these: compound 2.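

In this assay, among the compounds shown here, the ring on this carbonyl carbon can lower the number as well as raise it: the earlier rings gave only rises from compound 1, whereas 6-chloropyridin-3-yl gives a 4.2-fold lower number from compound 1 to compound 4 (0.62 log units; beyond the scatter) and a 9.8-fold lower number from compound 3 to compound 4 (0.99 log units; beyond the scatter), making compound 4 the lowest of the series so far. A halogen on this ring therefore does not by itself go with a high number, as the 4-bromo-2-fluorophenyl of compound 2 and the 6-chloropyridin-3-yl of compound 4 sit at opposite ends of the series, and the change between these rings gives an at least 21-fold lower number from compound 2 to compound 4 (1.33 log units; beyond the scatter). That step is bounded, as compound 2 stands at a limit of the measurement and not at a number: the limit of > 100000 nM in this assay, at which 1 of the 4 values shown sits.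

The compounds shown leave open whether the lower number goes with the ring nitrogen, the chlorine or the two together, as no pyridin-3-yl without chlorine and no 4-chlorophenyl stands among them. Also open, from the compounds shown here alone, is whether another group in the place of that chlorine, such as an amine or a methoxy on the pyridine ring, would keep, lower or raise the number.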